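The source may hold more compounds than are shown below. What is called first, only, known or untested is meant among the compounds shown, and "the series" means these compounds.

Going by the values given here, compound 2 `CS(=O)(=O)c1ccc(-c2cnc3[nH]cc(-c4nnc(-c5ccc(Cl)cc5)o4)c(=O)c3c2)cc1` stands highest of the two numbers so far in a functional assay on MCF7 cells (Homo sapiens) for inhibition, read by MTT assay, with a stated time of 24 h, tested at 10 uM; a higher number here means more inhibition of growth at the concentration tested, a lower number less inhibition of growth: compound 2 gives 13.1%. Its nearest neighbour is compound 1 `CS(=O)(=O)c1ccc(-c2cnc3[nH]cc(-c4nnc(-c5ccccc5)o4)c(=O)c3c2)cc1`, which in this assay gives 2.83%; the two differ only by chloro in place of hydrogen on an aromatic carbon, and that step reads a number 10.3 percentage points higher from compound 1 to compound 2 (beyond the scatter).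

Compound 3 `Cc1ccc(-c2nnc(-c3c[nH]c4ncc(-c5ccc(S(C)(=O)=O)cc5)cc4c3=O)o2)cc1` is not yet measured. It differs from compound 2 by methyl in place of chloro on an aromatic carbon. Among the compounds with values here, the only measured step that bears on this position is the one from compound 1 to compound 2, where adding chloro to the bare ring gave a modest rise. Within the data shown here, no measured pair shows methyl against chloro at that place, so the direction of the present change is not fixed by the data. Methyl and chloro are both single-heavy-atom groups at the same site, para to a large group, and the step from hydrogen to chloro was itself only modest; the expectation for compound 3 is therefore a step of a number 3.1 percentage points lower from compound 2 to compound 3 (within the scatter) in this assay, not beyond the scatter. Compound 3 is accordingly estimated at 10% in this assay, within a range from 0% to 24%.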

Compound 3, percent growth inhibition at one concentration: 10.6%
The estimate for compound 3 lay 0.6 percentage points below the measured number; low and high end bracket the measured number.
By their numbers in this assay, from the lowest: compounds 1, 3 and 2 (each within the scatter of the next, the first and the last beyond it).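

In this assay the change from 4-chlorophenyl to 4-methylphenyl reads a number 2.5 percentage points lower from compound 2 to compound 3 (within the scatter), so at this place, on an aromatic carbon para to a large group, methyl and chloro cannot be told apart. Against the bare ring, methyl reads a number 7.8 percentage points higher from compound 1 to compound 3 (within the scatter), while the chloro step reads a number 10.3 percentage points higher from compound 1 to compound 2 (beyond the scatter); compound 3 thus cannot be separated from either neighbour, and only the pair of compound 1 and compound 2 stays resolved, so the series gives a small difference at this place rather than a graded order among hydrogen, methyl and chloro. No measurement at hand offers an explanation for these readings.

Open, as far as these compounds go, is whether any group at this place moves the number well beyond the narrow band seen with hydrogen, methyl and chloro, for instance an amine, a carboxylic acid or a longer chain such as butyl. Also open is whether the small chloro step would hold on another core or at another place on the same ring, since the three compounds shown vary at this one site alone.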